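The source may report more compounds than this note shows. Statements on the series, on what has been measured and on what is new or still open speak of the compounds shown alone.

Measured so far in an ADME assay on MT4 cells (Homo sapiens) for cytotoxicity, read by MTT assay; a higher number here means that more compound is tolerated, a lower number that less compound is tolerated:
- compound 1 `O=c1cc(Cc2c(F)cccc2F)nc(Sc2ccccc2)[nH]1` gives > 76000 nM (a limit)
- compound 2 `O=c1cc(Cc2c(F)cccc2F)nc(SCCCc2ccccc2)[nH]1` gives 32000 nM (a number)
- compound 3 `CC(=O)CSc1nc(Cc2c(F)cccc2F)cc(=O)[nH]1` gives > 81000 nM (a limit)

Compound 3 holds only a limit, > 81000 nM in this read-out. Next comes compound 4 `O=C(CSc1nc(Cc2c(F)cccc2F)cc(=O)[nH]1)c1ccc([N+](=O)[O-])cc1`, with the change 4-nitrophenyl in place of methyl on a carbonyl carbon. Among the measured compounds shown here, the one readable step is an at least 2.5-fold higher number from compound 2 to compound 3 (0.40 log units; beyond the scatter) and it lies beyond the scatter, while a step that the two limits leave unreadable from compound 1 to compound 3 gives no size. Neither step is the same change as this one, so the guide is weak. For the measured compounds named here, compound 2, at 32000 nM in this series, is the only true number. A modest fall is expected in this assay as the estimated step of an at least 2.3-fold lower number from compound 3 to compound 4 (0.36 log units; beyond the scatter) for now. For compound 4 the estimated value is 35000 nM with an expected range from 10000 nM to 80000 nM in this read-out.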

Compound 4, half-maximal cytotoxic concentration: 22000 nM
The estimate for compound 4 lay 1.6-fold (0.20 log units) above the measured number, within the range that was stated.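

In this assay, 4-nitrophenyl in place of methyl on a carbonyl carbon gives an at least 3.6-fold lower number from compound 3 to compound 4 (0.56 log units; beyond the scatter). Among the compounds shown here, this is the first readable step at this carbonyl carbon, and it shows that the group held there can lower the tolerated concentration. Its size remains a lower bound, as compound 3 holds only a limit: the limit of > 81000 nM in this assay, at which 1 of the 4 values shown sits.

The compounds shown do not separate the contribution of the aromatic ring from that of the nitro group. A plain phenyl or an aminophenyl on the same carbonyl carbon would bear on that question.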